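A few compounds are considered here, and "the series" means these few. Any claim that something is new, unique, unknown or untested is made for them only; others in the source may bear on it.

Measured so far in a functional assay on NCI-H322M cells (Homo sapiens) for cytotoxicity, read by sulforhodamine B assay, with a stated time of 48 h; a lower number here means a stronger inhibitor of growth, a higher number a weaker inhibitor of growth:
- compound 1 `ClCc1ccc(Cn2cnc3c(Cl)ncnc32)cc1`: 4160 nM
- compound 2 `ClCc1cccc(Cn2cnc3ncnc(Cl)c32)c1`: 3460 nM
- compound 3 `ClCc1ccc(Cn2cnc3c(Cl)nc(Cl)nc32)cc1`: 25100 nM

Compounds 1 and 2 are built from the same atoms joined differently; the difference between the two cores is not broken down here. In this assay the two values of compound 1 and compound 2 lie within the usual scatter of each other, so no order between them can be drawn. Compound 3 differs from compound 1 in a single place: chloro in place of hydrogen on an aromatic carbon. This change made the step of a 6.0-fold higher number from compound 1 to compound 3 (0.78 log units; beyond the scatter), a weakening of growth inhibition that lies beyond the scatter.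

Compound 4 `ClCc1cccc(Cn2cnc3nc(Cl)nc(Cl)c32)c1` is not yet measured. It carries the same change onto compound 2: chloro in place of hydrogen on an aromatic carbon. Since the place described for this change is the same in both pairs, the change is the same. Going by the values given here, the only measured example of it is the step of a 6.0-fold higher number from compound 1 to compound 3 (0.78 log units; beyond the scatter), and on that example the expectation rests. A step of about a 5.2-fold higher number from compound 2 to compound 4 (0.72 log units; beyond the scatter) is expected from compound 2 to compound 4. Compound 4 is therefore estimated at about 18000 nM in this assay, with a range from 7000 nM to 45000 nM reflecting that a single earlier example supports this expectation.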

Compound 4, concentration for total growth inhibition: 26900 nM
Compound 4: the middle estimate sits 1.5-fold (0.17 log units) below what was measured, within the range that was stated.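

In this assay, chloro in place of hydrogen on an aromatic carbon gave a 7.8-fold higher number from compound 2 to compound 4 (0.89 log units; beyond the scatter), so growth inhibition weakened on this core as well. Set beside the earlier case, the step points the same way and is of matching size, which means that what was measured on one core carried over to the other: the same change on two cores in this assay, a 6.0-fold higher number (0.78 log units; beyond the scatter) from compound 1 to compound 3 and a 7.8-fold higher number (0.89 log units; beyond the scatter) from compound 2 to compound 4, 1.3-fold (0.11 log units) apart, within the scatter of two such steps. Going by these compounds alone, this rests on only two pairs of compounds in a single cell assay, so it does not show that the change would act alike on any other core or in other cells, and it does not explain why growth inhibition weakens.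

The compounds shown leave open what other groups would do on that same aromatic carbon between two ring nitrogen atoms, such as an amine, a methoxy group or a longer chain in place of the hydrogen. As far as these compounds go, it also remains open whether any such group would leave compound 2 near its 3460 nM or bring the number lower.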